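The source may report more compounds than this note shows. Statements on the series, on what has been measured and on what is new or still open speak of the compounds shown alone.

Compound 1 `COc1ccc2c(c1)OC(c1cc(OC)c(OC)c(OC)c1)C(CO)=C2` gives in a functional assay for inhibition of nuclear factor NF-kappa-B complex (Homo sapiens) (a lower number here means a stronger inhibitor, a higher number a weaker inhibitor), only a limit of the assay, > 50000 nM.
Compound 2 `COc1ccc2c(c1)OC(c1cc(OC)c(OC)c(OC)c1)C(C(=O)Nc1ccccc1)=C2` gives in this assay 17500 nM.
Compound 3 `CNC(=O)C1=Cc2ccc(OC)cc2OC1c1cc(OC)c(OC)c(OC)c1` gives in this assay only a limit, > 50000 nM.

Compound 3 thus sits at the limit of this assay, where two of the three values stand (the limit of > 50000 nM in this assay, at which 2 of the 3 values shown sit). Compound 4 `CCNC(=O)C1=Cc2ccc(OC)cc2OC1c1cc(OC)c(OC)c(OC)c1` differs from it by methyl in place of hydrogen on a saturated chain carbon bound to an amide-type nitrogen. Within the data shown here, the step of an at least 2.8-fold higher number from compound 2 to compound 3 (0.45 log units; beyond the scatter) is the one measured change at the amide-type nitrogen; the step that the two limits leave unreadable from compound 1 to compound 3 gives no size. Lengthening methyl to ethyl is a far smaller change than the swap of phenyl for methyl, so for compound 4 a step of a number no higher from compound 3 to compound 4 (the limit leaves the size open) of no size beyond the scatter is expected in this assay. Compound 4 is therefore estimated at 50000 nM, between 20000 nM and 100000 nM, most likely again reported as a limit.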

Compound 4, half-maximal inhibitory concentration: > 50000 nM
Compound 4: no number, only a limit (the forecaster's own chance of this, stated with the estimate: 70%); the middle value lies on the limit itself.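

Ethyl in place of phenyl on the amide-type nitrogen gives an at least 2.8-fold higher number from compound 2 to compound 4 (0.45 log units; beyond the scatter) in this assay, so ethyl, like methyl, leaves the amide without the readable value of compound 2. Among the amides shown, only the phenyl amide gives a number. The steps from compound 3 to compound 4 and from compound 1 to compound 4 cannot be read, because both ends of each sit at a limit: the limit of > 50000 nM in this assay, at which 3 of the 4 values shown sit.

As far as these compounds go, whether a benzyl group or a cyclohexyl ring on the amide-type nitrogen would also give a readable number stays open. So does whether a substituted phenyl would give a lower number than compound 2.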